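The source may hold more compounds than are shown below. What is called first, only, known or untested is meant among the compounds shown, and "the series" means these compounds.

Compound 1, `C#CCNC(=O)/C(C)=C(\C)c1cc(OC)c(OC)c(OC)c1`: in a toxicity assay on the whole organism (strain Icem-CET (SPF Caw)) for cytotoxicity, with Mus musculus as the target (a higher number here means that more compound is needed for the effect, a lower number that less compound is needed), compound 1 gives 300 mg/kg.
Compound 2, `C=CCNC(=O)/C(C)=C(\C)c1ccccc1`: compound 2 gives 300 mg/kg.
Compound 3, `C=CCNC(=O)/C(C)=C(/C)c1ccc(Cl)cc1`: compound 3 gives 280 mg/kg.

Among these three amides, compound 1 stands level with compound 2 at the digits shown, and together they hold the highest of the three numbers. Compound 3 is the furthest from compound 1, yet its number sits so close that the gap lies within the usual scatter of repeated measurements. Going by the values given here, no pair of measured compounds differs in a single place, so no measured step can be carried forward to the next compound.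

Compound 4, `COc1cc(/C(C)=C(\C)C(=O)NC2CC2)cc(OC)c1OC`, shares the core of compound 1 and departs from it at one point: cyclopropyl in place of propargyl on an amide-type nitrogen. Among the compounds with values here, there is no measured step of this kind to draw on, and the three numbers so far lie close together, so no shift beyond the scatter is expected in this assay for the step of no change at the digits printed from compound 1 to compound 4 (within the scatter). Compound 4 is therefore estimated at 300 mg/kg, with a range from 150 mg/kg to 600 mg/kg.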

Compound 4, dose for half-maximal effect: > 800 mg/kg
Compound 4 ended at the assay's limit (the forecaster's own chance of this, stated with the estimate: 5%); middle value at least 2.6-fold (0.42 log units) from the limit.
By their numbers in this assay, from the lowest: compounds 3, 1 and 2 (each within the scatter of the next). At a limit, above all of these: compound 4.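

Compound 4 gives > 800 mg/kg in this assay, and this value is a limit of the assay, not a number. Cyclopropyl in place of propargyl on an amide-type nitrogen gives an at least 2.6-fold higher number from compound 1 to compound 4 (0.42 log units; beyond the scatter), which shows that this position can move the result beyond the scatter even though both groups have three carbon atoms and the change leaves the rest of the core of compound 1 as it was. The size of this step is only a bound, and its true size remains unknown: the limit of > 800 mg/kg in this assay, at which 1 of the 4 values shown sits.

The compounds shown leave open whether the step follows from the loss of the triple bond or from the presence of the ring, which a plain propyl chain or a cyclobutyl ring on the same nitrogen could help to separate. They also leave open whether the same change would have a similar effect on a different core.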